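The source may hold more compounds than are shown below. What is called first, only, known or untested is meant among the compounds shown, and "the series" means these compounds.

Compound 1 `N#CC1=C(N)Oc2c(c3nc4ccccc4nc3c3ccccc23)C12C(=O)N(Cc1cnnn1-c1cccc(Cl)c1)c1ccccc12`: in a functional assay on HCT-116 cells (Homo sapiens) for antiproliferative activity, read by MTT assay, with a stated time of 48 h (a higher number here means a weaker inhibitor, a lower number a stronger inhibitor), compound 1 reaches only a limit of the assay, > 50000 nM.
Compound 2 `N#CC1=C(N)Oc2c(c3nc4ccccc4nc3c3ccccc23)C12C(=O)N(Cc1cnnn1-c1cccc(S(N)(=O)=O)c1)c1ccccc12`: in this assay compound 2 gives 11300 nM.
Compound 3 `Cc1ccc(-n2nncc2CN2C(=O)C3(C(C#N)=C(N)Oc4c3c3nc5ccccc5nc3c3ccccc43)c3ccccc32)c(C)c1`: in this assay compound 3 again reaches only a limit of the assay, > 50000 nM.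

For the measured compounds named here, compound 1 therefore stands at the limit of this assay, as the limit of > 50000 nM in this assay, at which 2 of the 3 values shown sit, records, and compound 2 is the only measured compound with a number. Compound 4 `Cc1ccc(-n2nncc2CN2C(=O)C3(C(C#N)=C(N)Oc4c3c3nc5ccccc5nc3c3ccccc43)c3ccccc32)cc1Cl` differs from compound 1 by methyl in place of hydrogen on an aromatic carbon.

Going by the values given here, no measured step touches this position. The step of an at least 4.4-fold lower number from compound 1 to compound 2 (0.64 log units; beyond the scatter) exchanges the chloro group, and the step of an at least 4.4-fold higher number from compound 2 to compound 3 (0.64 log units; beyond the scatter) returns the number to the limit when a 2,4-dimethylphenyl group stands on the aromatic nitrogen. The step that the two limits leave unreadable from compound 1 to compound 3 runs from one limit to the other, so two methyl-bearing phenyl rings already sit at the limit. Adding a methyl to the 3-chlorophenyl ring of compound 1 is therefore expected to give no step beyond the scatter, a number no higher from compound 1 to compound 4 (the limit leaves the size open), with the value most likely remaining a limit. Compound 4 is estimated at 50000 nM in this assay, between 20000 nM and 150000 nM.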

Compound 4, half-maximal inhibitory concentration: > 50000 nM
Compound 4 ended at the assay's limit (the forecaster's own chance of this, stated with the estimate: 75%); the middle value lies on the limit itself.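

Placing a methyl group ortho to the chloro group, which turns 3-chlorophenyl into 3-chloro-4-methylphenyl, gives a first reading at this position, and that reading is only a limit: the limit of > 50000 nM in this assay, at which 3 of the 4 values shown sit. The steps from compound 1 to compound 4 and from compound 3 to compound 4 run from limit to limit and cannot be read. The one readable step is an at least 4.4-fold higher number from compound 2 to compound 4 (0.64 log units; beyond the scatter), so among the four compounds shown, only the 3-sulfamoylphenyl ring of compound 2 gives a number.

As far as these compounds go, whether the methyl group changes anything at all remains open, since compound 1 and compound 4 both sit at the limit. Also open, from the compounds shown here alone, is how an amine, a carboxylic acid or a methoxy group would read at this position, and whether any of them would bring a number within the range of this assay.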